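The compounds below may be only part of what the source reports. "The series", "measured", "known", "first", "only" and "open" are said of these compounds alone.

Of the compounds shown here, three of one shared core have been measured in a functional assay on NCI-H1975 cells (Homo sapiens) for cytotoxicity, read by CCK-8 assay, with a stated time of 72 h; a lower number here means a stronger inhibitor, a higher number a weaker inhibitor. Compound 1, with the structure `C=CCn1c(=O)/c(=C\c2cccc(F)c2)[nH]c(=O)/c1=C\c1ccccc1OC`, gives 25600 nM in this assay, which is the higher of the two numbers reported. Compound 3, the structure `COc1ccccc1/C=c1/[nH]c(=O)/c(=C\c2nc[nH]c2C(C)(C)C)[nH]c1=O`, gives 100 nM in this assay, a far lower number, well beyond the scatter; it differs from compound 1 in more than one place, so the two values can only be compared, not traced to a single change. Compound 2, the structure `C=CCn1c(=O)/c(=C\c2cccc(Br)c2)[nH]c(=O)/c1=C\c1cccc(Br)c1`, is reported in this assay as "not active" (no number reported), without a number.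

The next compound, compound 4 with the structure `C=CCn1c(=O)/c(=C\c2ccccc2Cl)[nH]c(=O)/c1=C\c1ccccc1OC`, keeps everything of compound 1 except one group: 2-chlorophenyl in place of 3-fluorophenyl on a double-bonded chain carbon bound to an aromatic carbon. Among the measured compounds shown here, no pair of measured compounds shows what such a swap does on this core. For the measured compounds named here, the only guidance is that compound 1 sits high in this assay and that compound 2, carrying bromine on both rings, gave no number at all, so a large improvement is not expected.

The step from compound 1 to compound 4 is expected to be small, a 1.4-fold lower number from compound 1 to compound 4 (0.15 log units; within the scatter), within or barely beyond the scatter. Compound 4 is therefore estimated at 18000 nM in this assay, with a range from 6000 nM to 55000 nM.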

Compound 4, half-maximal inhibitory concentration: 9200 nM
The estimate for compound 4 lay 2.0-fold (0.29 log units) above the measured number; low and high end bracket the measured number.
By their numbers in this assay, from the lowest: compound 3; then compound 4; then compound 1.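

In this assay, among the compounds shown here, 2-chlorophenyl in place of 3-fluorophenyl gives a 2.8-fold lower number from compound 1 to compound 4 (0.44 log units; beyond the scatter) and is the first direct reading of a single change on the shared core, showing that the group on this double-bonded chain carbon can shift the number by a modest amount beyond the scatter. As the two group names show, this swap changes both the halogen and its numbered ring position, so the step cannot be assigned to either change alone. No measurement shown here explains the step, so the result stands as an observation without a known cause.

Still open is which of the two changes accounts for the step, a question that 3-chlorophenyl or 2-fluorophenyl at the same place on the core of compound 1 could help to answer. Also open, on these data alone, is how the number would respond to a phenyl ring carrying an amine or a carboxylic acid at this place, or to a longer chain in place of the ring.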